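Moving the methoxy group on the pendant phenyl ring

This account rests on a few compounds, and the source may have more. Where it says the series, first, only, none or still open, it means among the compounds named here.

Compound 1, `COc1cc(-n2cnc3ccc(-c4cccc(N)c4)cc32)cc(OC)c1OC`: 180 nM
Compound 2, `COc1cc(-n2cnc3ccc(-c4ccc(C(F)(F)F)cc4)cc32)cc(OC)c1OC`: 760 nM
Compound 3, `COc1cccc(-c2ccc3ncn(-c4cc(OC)c(OC)c(OC)c4)c3c2)c1`: 1610 nM

All three compounds were tested in a functional assay on MCF7 cells (Homo sapiens) for antiproliferative activity, read by MTT assay, with a stated time of 72 h; a higher number here means a weaker inhibitor, a lower number a stronger inhibitor. Compound 3, `COc1cccc(-c2ccc3ncn(-c4cc(OC)c(OC)c(OC)c4)c3c2)c1`, gives the highest number of the three; its nearest neighbour is compound 2, which lies a 2.1-fold higher number from compound 2 to compound 3 (0.33 log units; beyond the scatter), while compound 1 lies furthest away, an 8.9-fold higher number from compound 1 to compound 3 (0.95 log units; beyond the scatter). Compound 2 itself sits a 4.2-fold higher number from compound 1 to compound 2 (0.63 log units; beyond the scatter).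

Compound 4, `COc1ccccc1-c1ccc2ncn(-c3cc(OC)c(OC)c(OC)c3)c2c1`, differs from compound 3 in one place: 2-methoxyphenyl in place of 3-methoxyphenyl on an aromatic carbon. For the measured compounds named here, none of the measured steps moves the methoxy group around the pendant phenyl ring; the known steps swap the group itself or its partner ring, and those gave modest shifts. Going by the values given here, with no direct precedent, the expected step in this assay, a 1.1-fold lower number from compound 3 to compound 4 (0.03 log units; within the scatter), is small and of uncertain direction, likely within the scatter. Compound 4 is therefore estimated at 1500 nM, with a range from 500 nM to 4500 nM.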

Compound 4, half-maximal inhibitory concentration: 1750 nM
Compound 4: the middle estimate sits 1.2-fold (0.07 log units) below what was measured; measured number inside the range.
By their numbers in this assay, from the lowest: compound 1; then compound 2; then compounds 3 and 4 (each within the scatter of the next).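

In this assay, for the compounds shown here, exchanging 3-methoxyphenyl for 2-methoxyphenyl gives a 1.1-fold higher number from compound 3 to compound 4 (0.04 log units; within the scatter), the first direct look at where the methoxy group sits on the pendant ring, and the two placements cannot be told apart here. The change also leaves the wider picture intact: the new compound shows a 2.3-fold higher number from compound 2 to compound 4 (0.36 log units; beyond the scatter) and a 9.7-fold higher number from compound 1 to compound 4 (0.99 log units; beyond the scatter), so both methoxy compounds remain behind the 3-aminophenyl compound, and compound 1 keeps the lowest number. No available evidence bears on this result.

As far as these compounds go, whether 4-methoxyphenyl would fit alongside these two placements remains open. So does the question of whether a 2-aminophenyl or 4-aminophenyl group would match the 3-aminophenyl group of compound 1, or whether the amino group's placement matters more than the methoxy group's did.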